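The compounds below may be only part of what the source reports. "The series", "measured", "known", "first", "only" and "open" are said of these compounds alone.

Measured so far:
compound 1 `CCOC(=O)c1[nH]c2cc(Cl)ccc2c1/C=N/NC(=O)Cc1cccs1` — in an assay for inhibition of Polyunsaturated fatty acid lipoxygenase ALOX15 (Homo sapiens), with a stated time of 8 min (a higher number here means a weaker inhibitor, a lower number a stronger inhibitor), a limit, > 10000 nM.
compound 2 `CCOC(=O)c1[nH]c2cc(Cl)ccc2c1/C=N/NC(=O)CC1CCCC1` — in this assay a limit, > 10000 nM.

Compound 2 stands in this assay only at a limit; no number exists for it, and the same holds for compound 1. The step that the two limits leave unreadable from compound 1 to compound 2 is therefore unreadable, because both values sit at the limit of > 10000 nM in this assay, at which 2 of the 2 values shown sit. Whether swapping a thiophen-2-yl for a cyclopentyl on that chain carbon changes anything within the shared core cannot be said from these two points.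

Compound 3 `CCOC(=O)c1[nH]c2cc(Cl)ccc2c1/C=N/NC(=O)COc1ccc([N+](=O)[O-])cc1` carries the change (4-nitrophenoxy in place of cyclopentyl on a saturated chain carbon bound to a carbonyl carbon). For the measured compounds named here, no measured step bears on this exchange in a readable way; the only information is that both measured compounds sit at the limit. The expectation for compound 3 in this assay is accordingly that it again comes out weak, most likely as a limit rather than a number. Compound 3 is estimated at 15000 nM, with a range from 3000 nM to 60000 nM. The expected step is a step that the limit leaves unreadable from compound 2 to compound 3, not distinguishable from none.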

Compound 3, half-maximal inhibitory concentration: > 10000 nM
Compound 3 was reported as a limit (the forecaster's own chance of this, stated with the estimate: 70%); the middle value is on the limit's open side.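

For the compounds shown here, no step among compound 1, compound 2 and compound 3 can be read in this assay, because all three values are limits: the limit of > 10000 nM in this assay, at which 3 of the 3 values shown sit.

The compounds shown leave open whether any group at that chain carbon of the shared core gives a measurable inhibition.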